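Working notes: substituent swaps on the benzyl ether ring

This account rests on a few compounds, and the source may have more. Where it says the series, first, only, none or still open, it means among the compounds named here.

Measured so far:
Compound 1 `CCOC(=O)c1cc(-c2cccc(OCc3cccc(F)c3)c2)on1` — in an ADME assay on Vero cells (Chlorocebus sabaeus) for cytotoxicity, with a stated time of 72 h (a higher number here means a weaker inhibitor, a lower number a stronger inhibitor), compound 1 gives > 128000 nM, which is a limit of the assay.
Compound 2 `CCOC(=O)c1cc(-c2cccc(OCc3cccc(Br)c3)c2)on1` — in this assay compound 2 gives > 128000 nM, likewise a limit of the assay.
Compound 3 `CCOC(=O)c1cc(-c2cccc(OCc3cccc(OC(F)(F)F)c3)c2)on1` — in this assay compound 3 gives 101000 nM.

Among the measured compounds shown here, compound 3 thus holds the only number in the set; the two other values sit at the limit of > 128000 nM in this assay, at which 2 of the 3 values shown sit. The step from compound 1 to compound 2 is a step that the two limits leave unreadable from compound 1 to compound 2. The two steps that end at compound 3 are an at least 1.2-fold lower number from compound 1 to compound 3 (0.10 log units; that floor lies within the scatter) and an at least 1.2-fold lower number from compound 2 to compound 3 (0.10 log units; that floor lies within the scatter); each is only a floor, and that floor lies within the scatter.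

Compound 4 `CCOC(=O)c1cc(-c2cccc(OCc3cccc(N)c3)c2)on1` carries amino in place of trifluoromethoxy on an aromatic carbon. The steps to compound 3 show that swapping the group on that aromatic carbon moved the read-out little if at all, so for compound 4 a step of about a 1.1-fold higher number from compound 3 to compound 4 (0.06 log units; within the scatter) is expected, not beyond the scatter, with a fair chance that only a limit is reported. The value expected for compound 4 in this assay is 115000 nM, between 55000 nM and 200000 nM.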

Compound 4, half-maximal inhibitory concentration: > 128000 nM
Compound 4: no number, only a limit; the forecaster's own chance of this, stated with the estimate: 55%; at least 1.1-fold (0.04 log units) between middle value and limit.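

In this assay the new result gives only an at least 1.2-fold higher number from compound 3 to compound 4 (0.10 log units; that floor lies within the scatter), so this swap yields no readable change. Amino brings 1 heavy atom and 1 hydrogen-bond donor where trifluoromethoxy had 5 heavy atoms and 0 hydrogen-bond donors, yet this large change in the group on that aromatic carbon still gives no number in the readable range. The steps to compound 4 from compound 1 and from compound 2 cannot be read, and the set now rests mostly on one limit: the limit of > 128000 nM in this assay, at which 3 of the 4 values shown sit.

From the compounds shown here alone, whether compound 3 truly differs from the other three compounds remains open, since it alone has a number and each of its steps is only a floor. Also open, going by these compounds, is whether a carboxylic acid or a longer chain on this aromatic carbon would give a number clearly different from that of compound 3.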